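Adding a Second Trifluoromethyl Group to the Aryl Ring

The source may report more compounds than this note shows. Statements on the series, on what has been measured and on what is new or still open speak of the compounds shown alone.

Three compounds share one core and were tested in a functional assay on CHO cells for agonist activity at adenosine receptor A1 (Homo sapiens), read by fluorescence and ERK phosphorylation, with stated times of 30 min and 1.5 h, tested at 3 uM; on this read-out higher numbers stand for a stronger effect at the one concentration tested and lower numbers for a weaker effect. Compound 1 `Nc1scc(-c2cc(C(F)(F)F)cc(C(F)(F)F)c2)c1C(=O)c1ccccc1` gives 83%, compound 3 `Nc1scc(-c2cccc(F)c2)c1C(=O)c1ccc(Cl)cc1` gives 76%, and compound 2 `Nc1scc(-c2cccc(C(F)(F)F)c2)c1C(=O)c1ccc(Cl)cc1` gives 64%, the lowest of the three numbers. For the measured compounds named here, the only single-point step known, a number 12 percentage points higher from compound 2 to compound 3 (beyond the scatter), shows that swapping one group on that aromatic ring can move the read-out beyond the scatter. Compound 4 `Nc1scc(-c2cc(C(F)(F)F)cc(C(F)(F)F)c2)c1C(=O)c1ccc(Cl)cc1` differs from compound 2 by trifluoromethyl in place of hydrogen on an aromatic carbon. Going by the values given here, no measured pair isolates this exact change, but compound 1 carries the same two trifluoromethyl groups and gives 83%. Compound 4 is therefore expected to gain, with a step of about a number 11 percentage points higher from compound 2 to compound 4 (beyond the scatter), to an estimated 75% within 60% to 90%.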

Compound 4, a percentage reported as activity, at one concentration (the size of the read-out at that concentration, not a potency): 69%
Compound 4: middle estimate off by 6 percentage points, on the high side; the measured number falls inside the stated range.
By their numbers in this assay, from the lowest: compounds 2, 4, 3 and 1 (each within the scatter of the next, the first and the last beyond it).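

In this assay, the added trifluoromethyl group gives a number 5 percentage points higher from compound 2 to compound 4 (within the scatter) and so brings no clear gain at this position, despite the high number of compound 1. With both trifluoromethyl groups present, chloro in place of hydrogen on the other aromatic ring gives a number 14 percentage points lower from compound 1 to compound 4 (beyond the scatter), so the number of compound 1 does not carry over to compound 4. No available evidence explains either step. The compounds shown leave open how an amine or a carboxylic acid in place of this trifluoromethyl group would read, and whether a methoxy group in place of chloro would give the same step.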